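Compound 1 to compound 3: changing one indolyl group

This account rests on a few compounds, and the source may have more. Where it says the series, first, only, none or still open, it means among the compounds named here.

In a functional assay on HCT-116 cells (Homo sapiens) for antiproliferative activity, with a stated time of 72 h (on this read-out lower numbers stand for stronger inhibition and higher numbers for weaker inhibition), compound 1 `O=C(COc1ccc(CN2CC=C(c3c[nH]c4cccc(F)c34)CC2)c(F)c1)NO` gives 1220 nM and compound 2 `O=C(COc1ccc(CN2CC=C(c3c[nH]c4cccc(F)c34)CC2)cc1)NO` gives 969 nM, so the two sit within the scatter of each other: a 1.3-fold lower number from compound 1 to compound 2 (0.10 log units; within the scatter), with hydrogen in place of fluoro on an aromatic carbon. Compound 3 `Cc1[nH]c2ccccc2c1C1=CCN(Cc2ccc(OCC(=O)NO)cc2F)CC1` changes another place: 2-methyl-1H-indol-3-yl in place of 4-fluoro-1H-indol-3-yl on a double-bonded ring carbon. Among the measured compounds shown here, no measured step covers this swap, so the estimate stays close to compound 1 at 1220 nM. The expected change is a 1.2-fold lower number from compound 1 to compound 3 (0.09 log units; within the scatter), none beyond the scatter. Compound 3 is estimated at 1000 nM, within an expected range of 300 nM to 3300 nM.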

Compound 3, half-maximal inhibitory concentration: 1220 nM
The estimate for compound 3 lay 1.2-fold (0.09 log units) below the measured number; low and high end bracket the measured number.
By their numbers in this assay, from the lowest: compounds 2, 1 and 3 (each within the scatter of the next).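

Within this assay putting 2-methyl-1H-indol-3-yl in place of 4-fluoro-1H-indol-3-yl on the double-bonded ring carbon gives no change at the digits printed from compound 1 to compound 3 (within the scatter) and this is the first look at this position. Here, one substituted indolyl group can stand in for the other without a read-out difference beyond the scatter. No available evidence accounts for this result.

Going by these compounds, this single step removes the fluoro and adds the methyl together, so their separate contributions stay unknown. Also open, on these data alone, is what an unsubstituted 1H-indol-3-yl or a phenyl group would give at this carbon.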